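This account rests on a few compounds, and the source may have more. Where it says the series, first, only, none or still open, it means among the compounds named here.

The measured compounds:
compound 1, `CS(=O)(=O)NC1CCC(CN2CCN(c3cc(=O)c4cc(C(F)(F)F)cc([N+](=O)[O-])c4s3)CC2)CC1`; in an ADME assay on Vero cells (Chlorocebus sabaeus) for cytotoxicity, read by MTT assay, with a stated time of 48 h (a lower number here means a stronger inhibitor, a higher number a weaker inhibitor), compound 1 gives 48.5 ug/mL.
compound 2, `O=c1cc(N2CCN(CC3CCC(NS(=O)(=O)c4ccccc4)CC3)CC2)sc2c([N+](=O)[O-])cc(C(F)(F)F)cc12`; in this assay compound 2 gives > 64 ug/mL, which is a limit of the assay and not a number.

Going by the values given here, the one measured step is an at least 1.3-fold higher number from compound 1 to compound 2 (0.12 log units; that floor lies within the scatter); its true size cannot be fixed because of the limit of > 64 ug/mL in this assay, at which 1 of the 2 values shown sits. Compound 2 therefore stands at that limit, with no number of its own, at the weak end of what the assay can report.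

Compound 3 is `O=C(OC1CCC(CN2CCN(c3cc(=O)c4cc(C(F)(F)F)cc([N+](=O)[O-])c4s3)CC2)CC1)C1CCCCC1`. It differs from compound 2 in that ((cyclohexylcarbonyl)oxy in place of (phenylsulfonyl)amino on a saturated ring carbon). Among the compounds with values here, no measured step changes this part of the structure: the only step on record alters the group on the sulfonyl sulfur and keeps the (phenylsulfonyl)amino group that now leaves. Within the data shown here, that step shows only that a change on this side chain moved the number, if at all, by an amount within the scatter. In this assay compound 3 is expected to sit near the limit, giving an estimated 64 ug/mL within 32 ug/mL to 128 ug/mL. The expected step is a number no higher from compound 2 to compound 3 (the limit leaves the size open), not beyond the scatter.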

Compound 3, half-maximal inhibitory concentration: > 64 ug/mL
Compound 3 ended at the assay's limit (the forecaster's own chance of this, stated with the estimate: 55%); the middle value lies on the limit itself.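

Exchanging the whole group on the saturated ring carbon, and not only what sits on the sulfonyl sulfur, gives an at least 1.3-fold higher number from compound 1 to compound 3 (0.12 log units; that floor lies within the scatter) in this assay. Compound 3 gives > 64 ug/mL, which is a limit of the assay and not a number. The earlier compounds shown here both carried a sulfonyl group on an amino nitrogen, whereas the (cyclohexylcarbonyl)oxy group of compound 3 has neither that sulfonyl group nor a hydrogen-bond donor, so neither feature is needed on this ring carbon for a reading at the limit.

As far as these compounds go, the step between compound 2 and compound 3 cannot be read, and any difference between them stays open, because both values are the same limit: the limit of > 64 ug/mL in this assay, at which 2 of the 3 values shown sit. Also open is where an amine, a carboxylic acid or a longer carbon chain on this saturated ring carbon would stand in this assay, and whether any such group would give a number clearly lower than that of compound 1.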